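The source may report more compounds than this note shows. Statements on the series, on what has been measured and on what is new or still open speak of the compounds shown alone.

Three small biaryls have been tested in an assay on COS-7 cells for inhibition of patatin-like phospholipase domain-containing protein 2 (Mus musculus); a higher number here means a weaker inhibitor, a lower number a stronger inhibitor. Compound 1 `CCOC(=O)c1cccc(-c2cccs2)c1` gives 90000 nM. Compound 2 `CCOC(=O)c1cccc(-c2ccc(CN3CCCC3)cc2)c1` reaches only a limit of the measurement, > 200000 nM. Compound 3 `CCOc1ccc(-c2ccccc2)cc1` likewise stands at a limit, > 200000 nM, and so has no number of its own; that limit is the limit of > 200000 nM in this assay, at which 2 of the 3 values shown sit. Compound 4 `CCOc1ccc(-c2cccc(NC(=O)N(C)C)c2)cc1` differs from compound 3 in one place: (dimethylcarbamoyl)amino in place of hydrogen on an aromatic carbon, the new group sitting meta to a group of 9 heavy atoms. Within the data shown here, because compound 3 rests at the limit of > 200000 nM in this assay, at which 2 of the 3 values shown sit, no measured step gives a direction to lean on. A modest gain is nonetheless expected, and the step from compound 3 to compound 4 is estimated at an at least 2.0-fold lower number from compound 3 to compound 4 (0.30 log units; that floor lies within the scatter). Compound 4 is expected to give about 100000 nM, most likely between 20000 nM and 200000 nM.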

Compound 4, half-maximal inhibitory concentration: 70000 nM
Estimate against measurement, compound 4: 1.4-fold (0.15 log units) above; low and high end bracket the measured number.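

In this assay, among these compounds, putting (dimethylcarbamoyl)amino in place of hydrogen on this aromatic carbon, meta to a group of 9 heavy atoms, gives the first step that can be read here: an at least 2.8-fold lower number from compound 3 to compound 4 (0.45 log units; beyond the scatter). Compound 3 has only a limit, not a number of its own: the limit of > 200000 nM in this assay, at which 2 of the 4 values shown sit. The step therefore shows that a change at this one position can bring the series off that limit, but it fixes only a minimum size.

Going by these compounds, whether a simple amine or a carboxylic acid at the same position would do as much remains open. So does whether (dimethylcarbamoyl)amino would have a similar effect on the core of compound 1.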